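This account rests on a few compounds, and the source may have more. Where it says the series, first, only, none or still open, it means among the compounds named here.

Values in an assay on cells for agonist activity at vitamin D3 receptor (Homo sapiens), with a stated time of 96 h (a higher number here means that more compound is needed for the effect, a lower number that less compound is needed), for the measured compounds:

compound 1 `CCn1c(C(=O)NCCCN(C)C)ccc1C(CC)(CC)c1ccc(OCCC(O)(CC)CC)c(C)c1`: 5 nM
compound 2 `CCn1c(C(=O)NCC#N)ccc1C(CC)(CC)c1ccc(OCCC(O)(CC)CC)c(C)c1`: 1080 nM
compound 3 `C#CCCOC(=O)c1ccc(C(CC)(CC)c2ccc(OCCC(O)(CC)CC)c(C)c2)n1CC`: 6030 nM

Compound 2 stands second highest of these three numbers. Its nearest neighbour is compound 3, a 5.6-fold higher number from compound 2 to compound 3 (0.75 log units; beyond the scatter); the furthest is compound 1, a 220-fold higher number from compound 1 to compound 2 (2.33 log units; beyond the scatter). All three share the same core and differ only in the group on the carbonyl carbon.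

Compound 4 `CCC(C)C(CO)NC(=O)c1ccc(C(CC)(CC)c2ccc(OCCC(O)(CC)CC)c(C)c2)n1CC` has not yet been measured in this assay. Against compound 2 the change is 1-(hydroxymethyl)-2-methylbutyl in place of cyanomethyl on an amide-type nitrogen.

Among the compounds with values here, two measured steps touch the same part of the molecule. The step of a 220-fold higher number from compound 1 to compound 2 (2.33 log units; beyond the scatter) shows that the substituent on this amide-type nitrogen moves the number a great deal, with the larger chain of compound 1 giving by far the lowest number of the three. The step of a 5.6-fold higher number from compound 2 to compound 3 (0.75 log units; beyond the scatter), which removes the amide nitrogen altogether, raises the number further. The group entering in compound 4 is larger than cyanomethyl and carries one hydrogen-bond donor, but it is not the dimethylamino-bearing chain of compound 1, so the full reversal of the step from compound 1 to compound 2 is not expected. A step down from compound 2 is expected, a 7.2-fold lower number from compound 2 to compound 4 (0.86 log units; beyond the scatter), of a size between modest and large. Compound 4 is therefore estimated at 150 nM, in the range 30 nM to 800 nM.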

Compound 4, half-maximal effective concentration: 450 nM
Beside the measured number, compound 4's estimate is 3.0-fold (0.48 log units) below it; the measured number falls inside the stated range.
By their numbers in this assay, from the lowest: compound 1; then compound 4; then compound 2; then compound 3.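

In this assay, a larger branched chain with one hydrogen-bond donor on the amide-type nitrogen gives only a 2.4-fold lower number from compound 2 to compound 4 (0.38 log units; beyond the scatter), so replacing cyanomethyl with 1-(hydroxymethyl)-2-methylbutyl recovers little of the ground separating compound 2 from compound 1. The remaining gap of a 90-fold higher number from compound 1 to compound 4 (1.95 log units; beyond the scatter) leaves compound 1 alone at the low end of the series, which shows that size and a hydrogen-bond donor on this chain do not by themselves reproduce the number given by the 3-(dimethylamino)propyl group. The amide of compound 4 still stands well clear of the (but-3-yn-1-yl)oxy group, at a 13-fold lower number from compound 3 to compound 4 (1.13 log units; beyond the scatter), but no available evidence explains the sizes of these steps.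

Still open, as far as these compounds go, is whether the low number of compound 1 depends on the terminal dimethylamino group or on the three-carbon chain carrying it, a question that a plain pentyl chain or a 3-hydroxypropyl chain on this nitrogen would address. Also open, from the compounds shown here alone, is what the hydroxyl of compound 4 contributes, which the same branched chain ending in a methyl group or a carboxylic acid would help to separate.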